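The compounds below may be only part of what the source reports. "The series", "measured", "known", "first", "only" and "open" are said of these compounds alone.

Of the compounds shown here, three sharing one core have been measured in a functional assay on HL-60 cells (Homo sapiens) for cytotoxicity, read by WST assay, with a stated time of 48 h; on this read-out lower numbers stand for stronger inhibition and higher numbers for weaker inhibition. Compound 1 `O[C@@H](c1ccccc1)[C@H]1CO[C@H](c2ccccc2)[C@@H](C/C=C/c2cccc(F)c2)C1` gives 9170 nM in this assay, the lowest of the three numbers. Compound 3 `COc1ccccc1/C=C/C[C@H]1C[C@@H]([C@@H](O)c2ccccc2)CO[C@@H]1c1ccccc1` gives 10100 nM and compound 2 `O[C@@H](c1ccccc1)[C@H]1CO[C@H](c2ccccc2)[C@@H](C/C=C/c2ccccn2)C1` gives 36400 nM. Going by the values given here, exchanging the aryl on the double-bonded chain carbon has so far produced either no measurable step, as in a 1.1-fold higher number from compound 1 to compound 3 (0.04 log units; within the scatter), or a modest one, as in a 4.0-fold higher number from compound 1 to compound 2 (0.60 log units; beyond the scatter) and in a 3.6-fold lower number from compound 2 to compound 3 (0.56 log units; beyond the scatter).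

The unmeasured compound 4 `Oc1cccc(/C=C/C[C@H]2C[C@@H]([C@@H](O)c3ccccc3)CO[C@@H]2c2ccccc2)c1` differs from compound 1 by hydroxy in place of fluoro on an aromatic carbon. Among the compounds with values here, no measured step exchanges a fluoro for a hydroxy; the steps that bear on it are those that alter the same aryl, namely the step from compound 1 to compound 3, which stayed within the scatter, and the step from compound 1 to compound 2, which was modest and went toward a higher number. A small step in this assay is therefore expected for compound 4, leaning slightly toward a higher number, as a 1.3-fold higher number from compound 1 to compound 4 (0.12 log units; within the scatter). Compound 4 is estimated at 12000 nM, with a range from 5000 nM to 30000 nM.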

Compound 4, half-maximal inhibitory concentration: 12800 nM
The estimate for compound 4 lay 1.1-fold (0.03 log units) below the measured number; low and high end bracket the measured number.
By their numbers in this assay, from the lowest: compounds 1, 3 and 4 (each within the scatter of the next); then compound 2.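

In this assay, hydroxy in place of fluoro on an aromatic carbon, meta to a large group, brings in a hydrogen-bond donor and a hydrogen-bond acceptor, yet the step stays within the scatter (a 1.4-fold higher number from compound 1 to compound 4 (0.14 log units; within the scatter)), so this exchange on the 3-fluorophenyl ring leaves no measurable trace in this cytotoxicity read-out. The 3-hydroxyphenyl group also cannot be told apart from the 2-methoxyphenyl group (a 1.3-fold higher number from compound 3 to compound 4 (0.10 log units; within the scatter)), while it does stand apart from pyridin-2-yl (a 2.8-fold lower number from compound 2 to compound 4 (0.45 log units; beyond the scatter)), which leaves compound 2 as the only one of the four separated from all the others by steps beyond the scatter. Nothing shown here accounts for why these exchanges do or do not shift the number.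

The compounds shown leave open whether an amine or a carboxylic acid at this same place on the ring would also stay within the scatter of compound 1. They also leave open whether pyridin-3-yl would give a number like that of compound 2, and what a longer chain between the double bond and the shared core would do.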